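The source may hold more compounds than are shown below. What is called first, only, known or untested is meant among the compounds shown, and "the series" means these compounds.

Measured in a functional assay on A549 cells (Homo sapiens) for antiproliferative activity, read by MTT assay, with a stated time of 72 h; a lower number here means a stronger inhibitor, a higher number a weaker inhibitor:
- compound 1 `C/C=C/C(=O)Nc1cccc(Oc2nc(Nc3cccc(OC)c3)nc3c2CSCC3)c1`: 21100 nM
- compound 2 `COc1cccc(Nc2nc3c(c(Oc4cccc(NC(=O)C=C(C)C)c4)n2)CSCC3)c1`: 19800 nM

Compound 1 gives 21100 nM and compound 2 gives 19800 nM, so the two sit within the scatter of each other and neither can be ranked. Both are weak numbers on this assay.

The next compound to be read is compound 3 `C/C=C/C(=O)Nc1cccc(Oc2nc(Nc3cccc(C#N)c3)nc3c2CSCC3)c1`, which has cyano in place of methoxy on an aromatic carbon of compound 1: cyano in place of methoxy on an aromatic carbon. Going by the values given here, the only measured step is a 1.1-fold lower number from compound 1 to compound 2 (0.03 log units; within the scatter). That step lies within the scatter, but it concerns the group on the carbonyl carbon, and both of its compounds keep the (3-methoxyphenyl)amino group. Among the compounds with values here, no measured step therefore covers the change to 3-cyanophenyl, and the data give no firm direction. A modest move toward a lower number is expected, on weak grounds, and a result within the scatter would be no surprise. The expected change is a 1.4-fold lower number from compound 1 to compound 3 (0.15 log units; within the scatter). For compound 3 the estimated value is 15000 nM, with an expected range of 6000 nM to 35000 nM.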

Compound 3, half-maximal inhibitory concentration: 17200 nM
Compound 3: middle estimate off by 1.1-fold (0.06 log units), on the low side, and the stated range covers the measured number.
By their numbers in this assay, from the lowest: compounds 3, 2 and 1 (each within the scatter of the next).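

In this assay, going by these compounds alone, replacing methoxy with cyano on the aromatic carbon gives a 1.2-fold lower number from compound 1 to compound 3 (0.09 log units; within the scatter), the first reading for this part of the molecule, whereas the earlier step concerned only the group on the carbonyl carbon. The two groups match in the counts computed for them, with two heavy atoms, one hydrogen-bond acceptor, no hydrogen-bond donor and no net charge, and this exchange leaves compound 3 at 17200 nM, still a weak number and within the scatter of compound 1. Nothing available bears on why the number stays within the scatter for this exchange.

Among the compounds shown, only methoxy and cyano occupy this place, so it remains open whether an amine, a carboxylic acid or a longer alkoxy chain there would move the number beyond the scatter. Also open, on these data alone, is how the number would respond to cyano paired with 2-methylprop-1-en-1-yl on the carbonyl carbon, or to a dimethylamino group on the chain carried by the carbonyl carbon.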